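The source may report more compounds than this note shows. Statements on the series, on what has been measured and on what is new or still open speak of the compounds shown alone.

Working notes, compound 2 to compound 3.

Going by the values given here, compound 2 `O=C(Nc1cccc(NC(=O)c2ccccc2Cl)c1)c1cccc(Cl)c1` gives 2620 nM in an in vitro functional assay on HEK293-A cells for antagonist activity at metabotropic glutamate receptor 5 (Rattus norvegicus), read by calcium flux (a higher number here means a weaker inhibitor, a lower number a stronger inhibitor), and this is the only number in the set. In this assay compound 1 `COc1ccccc1C(=O)Nc1cccc(NC(=O)c2ccccc2Cl)c1` gives > 30000 nM, which is a limit and not a number, standing at the limit of > 30000 nM in this assay, at which 1 of the 2 values shown sits. Among the compounds with values here, the single measured step, an at least 11-fold lower number from compound 1 to compound 2 (1.05 log units; beyond the scatter), is large and runs toward a lower number; it exchanged a 2-methoxyphenyl for a 3-chlorophenyl on one carbonyl carbon.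

Compound 3 `O=C(Nc1cccc(NC(=O)c2cccc(Cl)c2)c1)c1cccc(F)c1` differs from compound 2 by 3-fluorophenyl in place of 2-chlorophenyl on a carbonyl carbon. Within the data shown here, the measured step bears on this only by analogy: again a 2-substituted phenyl on a carbonyl carbon gives way to a 3-substituted phenyl, but here a halogen is swapped for a halogen rather than a methoxy for a chloro, and compound 2 offers no direct precedent for the 3-fluorophenyl. A step toward a lower number in this assay is therefore expected, though a smaller one than the measured step, and the expected change is a 2.9-fold lower number from compound 2 to compound 3 (0.46 log units; beyond the scatter). Compound 3 is estimated at 900 nM, with a range from 250 nM to 3500 nM.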

Compound 3, half-maximal inhibitory concentration: > 30000 nM
Compound 3 gave a limit, no number; the forecaster's own chance of this, stated with the estimate: 5%; at least 33-fold (1.52 log units) between middle value and limit.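

In this assay the new step, an at least 11-fold higher number from compound 2 to compound 3 (1.05 log units; beyond the scatter), shows that this carbonyl carbon does not accept every halogen-bearing phenyl, and that the 3-chlorophenyl kept in compound 3 is not enough on its own to give a measurable number. Of the three compounds, only compound 2, which carries both 2-chlorophenyl and 3-chlorophenyl, falls short of the limit, so the gain seen at the earlier step depends on what sits at this second carbonyl carbon, a dependence the earlier pair could not show. The value for compound 3 is a limit and not a number, so the step gives only a minimum size and the two inactive compounds cannot be ranked against each other: the limit of > 30000 nM in this assay, at which 2 of the 3 values shown sit.

The compounds shown leave open whether the loss follows the change of chlorine to fluorine or the change from the 2-substituted to the 3-substituted phenyl, since both happen in this one step. A 2-fluorophenyl or a 3-chlorophenyl at this position would separate the two, and a 2-methylphenyl would test whether a halogen is needed at all.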